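Replacing bromo with trifluoromethoxy in compound 3

A few compounds are considered here, and "the series" means these few. Any claim that something is new, unique, unknown or untested is made for them only; others in the source may bear on it.

Values measured in a functional assay on DU-145 cells (Homo sapiens) for inhibition, read by trypan blue exclusion, with a stated time of 96 h (a lower number here means a stronger inhibitor of growth, a higher number a weaker inhibitor of growth), are these
Compound 1 `O=C(/C(=C\c1ccc(Cl)cc1)S(=O)(=O)c1ccc(Br)cc1)c1ccc(Br)cc1` gives 50000 nM
Compound 2 `O=C(/C(=C\c1ccc(Br)cc1)S(=O)(=O)c1ccc(Br)cc1)c1ccc(Br)cc1` gives 10000 nM

Compound 2 stands lowest of the two at 10000 nM and is the stronger inhibitor of growth so far. The change to compound 3 `O=C(/C(=C\c1ccc(OC(F)(F)F)cc1)S(=O)(=O)c1ccc(Br)cc1)c1ccc(Br)cc1` is trifluoromethoxy in place of bromo on an aromatic carbon. Within the data shown here, the only measured step bearing on this is a 5.0-fold lower number from compound 1 to compound 2 (0.70 log units; beyond the scatter) (modest, beyond the scatter, bromo in place of chloro at the same place). Among the measured compounds shown here, no measured compound carries trifluoromethoxy, so a similarly modest move toward a higher number is expected in this assay for this departure from bromo. The estimated step is a 2.5-fold higher number from compound 2 to compound 3 (0.40 log units; beyond the scatter) on this reasoning. Compound 3 is expected at 25000 nM within an estimated range of 8000 nM to 70000 nM by this reckoning.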

Compound 3, concentration for 50% growth inhibition: 25000 nM
Beside the measured number, compound 3's estimate shows no gap at the digits printed; measured number inside the range.
By their numbers in this assay, from the lowest: compound 2; then compounds 3 and 1 (each within the scatter of the next).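

In this assay, the larger trifluoromethoxy group does not match bromo at this place on the aromatic ring, with a 2.5-fold higher number from compound 2 to compound 3 (0.40 log units; beyond the scatter). Set against chloro, it gives a 2.0-fold lower number from compound 1 to compound 3 (0.30 log units; within the scatter), so these two groups cannot be separated here, and bromo alone stands clear of both others beyond the scatter. Nothing given here accounts for these differences. As far as these compounds go, whether an amine, a carboxylic acid or a methoxy group at this place would give a lower number than compound 2 remains open. So does whether the same order of groups would hold with changes elsewhere on the shared core.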